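The source may report more compounds than this note shows. Statements on the series, on what has been measured and on what is new or still open speak of the compounds shown alone.

Working notes on the series. Compound 1 (`CNc1nc(SCc2nc3ccccc3[nH]2)nc(-c2ccccc2)c1C#N`), compound 2 (`N#Cc1c(-c2ccccc2)nc(SCc2nc3ccccc3[nH]2)nc1N1CCNCC1`) and compound 3 (`CN1CCN(c2nc(SCc3nc4ccccc4[nH]3)nc(-c3ccccc3)c2C#N)CC1`) share one core and differ in the amine group on an aromatic carbon. In a functional assay on SK-MEL-28 cells (Homo sapiens) for cytotoxicity, read by MTT assay, with a stated time of 3 days (on this read-out lower numbers stand for stronger inhibition and higher numbers for weaker inhibition), compound 1 gives 2.87 nM and compound 2 gives 2.6 nM, a pair separated only by a 1.1-fold lower number from compound 1 to compound 2 (0.04 log units; within the scatter). Compound 3 gives 20 nM, the highest number of the three, reached by a 7.0-fold higher number from compound 1 to compound 3 (0.84 log units; beyond the scatter) and by a 7.7-fold higher number from compound 2 to compound 3 (0.89 log units; beyond the scatter).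

The next compound is compound 4 (`N#Cc1c(-c2ccccc2)nc(SCc2nc3ccccc3[nH]2)nc1N1CCN(S(=O)(=O)c2ccccc2)CC1`), with this change from compound 3: phenylsulfonyl in place of methyl on an amine nitrogen in a ring. In words, phenylsulfonyl stands in place of methyl on an amine nitrogen in a ring.

Going by the values given here, only one measured step changes that same nitrogen: a 7.7-fold higher number from compound 2 to compound 3 (0.89 log units; beyond the scatter). Among the compounds with values here, it replaces hydrogen with methyl, and no measured compound carries a group of the size of phenylsulfonyl there, so the step gives a direction only weakly and its size cannot be carried over directly. In this assay a small rise, probably within the scatter, is therefore expected, with a modest move in either direction remaining possible. The expected step is a 1.3-fold higher number from compound 3 to compound 4 (0.10 log units; within the scatter). For compound 4 the estimate is 25 nM, with an expected range from 5 nM to 130 nM.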

Compound 4, half-maximal inhibitory concentration: 6.41 nM
Compound 4: middle estimate off by 3.9-fold (0.59 log units), on the high side; low and high end bracket the measured number.
By their numbers in this assay, from the lowest: compounds 2 and 1 (each within the scatter of the next); then compound 4; then compound 3.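

On the ring nitrogen, size alone does not set the number in this assay: phenylsulfonyl, with 9 heavy atoms and a six-membered aromatic ring, gives a 3.1-fold lower number from compound 3 to compound 4 (0.49 log units; beyond the scatter) relative to the single carbon of methyl. Replacing the hydrogen with phenylsulfonyl still costs something, with a 2.5-fold higher number from compound 2 to compound 4 (0.39 log units; beyond the scatter), so the large group recovers only part of the ground lost with methyl. The numbers therefore run from hydrogen through phenylsulfonyl to methyl, which does not follow heavy-atom count; compound 3 is the one that goes against any steady rise with size. Nothing among the data shown accounts for this order.

The compounds shown leave open whether the lower number of compound 4 relative to compound 3 belongs to the sulfonyl link or to the phenyl ring, and a methylsulfonyl or a benzyl group on the same nitrogen would separate the two. Also open is whether the order holds for an acetyl group or a longer alkyl chain there, since methyl is the only alkyl group shown on this nitrogen.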